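Amidine to Nitrile: an Expected Loss in Cell Growth Inhibition

This account rests on a few compounds, and the source may have more. Where it says the series, first, only, none or still open, it means among the compounds named here.

Compound 1 `CCOC(=O)C(=O)N(Cc1cc(F)cc(F)c1)c1ccc2c(c1)OC(C)(CO)CN2C`: 44000 nM in a functional assay on HeLa cells (Homo sapiens) for antiproliferative activity, read by cell counting, with a stated time of 4 days; a lower number here means a stronger inhibitor, a higher number a weaker inhibitor
Compound 2 `CN1CC(C)(CO)Oc2cc(N(Cc3ccccc3)C(=O)C(=O)O)ccc21`: > 100000 nM in this assay
Compound 3 `CCOC(=O)CN(Cc1cc(F)cc(F)c1)c1ccc2c(c1)N(C)CC(C)(COc1ccc(C(=N)N)cc1)O2`: 4500 nM in this assay

For compound 2 the entry is a limit of this assay and not a number (the limit of > 100000 nM in this assay, at which 1 of the 3 values shown sits). Of the two numbers given, compound 3 has the lowest; compound 1 sits above it, beyond the usual scatter. Compound 4 `CCOC(=O)CN(Cc1cc(F)cc(F)c1)c1ccc2c(c1)N(C)CC(C)(COc1ccc(C#N)cc1)O2` is not yet measured. It differs from compound 3 at one point (a group of 2 heavy atoms (1 carbon, 1 nitrogen; no ring) in place of a group of 3 heavy atoms (1 carbon, 2 nitrogen; no ring), on an aromatic carbon). Among the compounds with values here, no directly comparable step exists, so the expectation rests on the values alone. The group that leaves sits on the arm present in compound 3 at 4500 nM but absent from compound 1 at 44000 nM. A moderate weakening is therefore expected a 4.4-fold higher number from compound 3 to compound 4 (0.65 log units; beyond the scatter). Compound 4 is estimated to give 20000 nM, within 6000 nM to 70000 nM.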

Compound 4, half-maximal inhibitory concentration: > 100000 nM
Compound 4: no number, only a limit; the forecaster's own chance of this, stated with the estimate: 15%; middle value at least 5.0-fold (0.69 log units) away from the limit.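

In this assay, within the data shown here, replacing the amidine with cyano on the aromatic carbon gives an at least 22-fold higher number from compound 3 to compound 4 (1.34 log units; beyond the scatter), the first single change that can be read at this place, and it shows that the activity of compound 3 depends strongly on the group there. Compound 4 gives > 100000 nM, which is a limit of the assay and not a number. The true size of the loss therefore stays unknown, because the reading stops at that limit: the limit of > 100000 nM in this assay, at which 2 of the 4 values shown sit.

The compounds shown leave open whether an amine or a carboxylic acid on this aromatic carbon would keep the activity of compound 3.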